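A Methyl Added to the Anilino Compound

This account rests on a few compounds, and the source may have more. Where it says the series, first, only, none or still open, it means among the compounds named here.

Compound 1 `COc1cc(C(=O)c2sc3ccccc3c2-c2ccc(Cl)cc2)cc(OC)c1OC` gives 3300 nM
Compound 2 `COc1ccccc1-c1c(C(=O)c2cc(OC)c(OC)c(OC)c2)sc2ccccc12` gives 2900 nM
Compound 3 `COc1cc(C(=O)c2sc3ccccc3c2Nc2ccccc2)cc(OC)c1OC` gives 5200 nM

All three values come from a functional assay on HL-60 cells (Homo sapiens) for antiproliferative activity, read by MTT assay, with a stated time of 72 h (on this read-out higher numbers stand for weaker inhibition and lower numbers for stronger inhibition), and lie close together. Compound 3 stands within the scatter of both other compounds. Compound 4 `COc1cc(C(=O)c2sc3ccccc3c2Nc2ccc(C)cc2)cc(OC)c1OC` differs from it by methyl in place of hydrogen on an aromatic carbon, para to a large group (methyl in place of hydrogen on an aromatic carbon). Going by the values given here, no measured step tests this change directly. The nearest steps exchange larger groups: a 1.1-fold lower number from compound 1 to compound 2 (0.06 log units; within the scatter), a 1.6-fold higher number from compound 1 to compound 3 (0.20 log units; within the scatter) and a 1.8-fold higher number from compound 2 to compound 3 (0.25 log units; within the scatter), all within the scatter. A smaller change is therefore expected to stay within the scatter too (a 1.3-fold lower number from compound 3 to compound 4 (0.11 log units; within the scatter)). For compound 4 the estimated value is 4000 nM (expected range 1300 nM to 10000 nM).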

Compound 4, half-maximal inhibitory concentration: 4600 nM
Compound 4: the middle estimate sits 1.2-fold (0.06 log units) below what was measured, within the range that was stated.
By their numbers in this assay, from the lowest: compounds 2, 1, 4 and 3 (each within the scatter of the next).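

In this assay, methyl in place of hydrogen on the anilino ring, para to a large group, leaves the number within the scatter (a 1.1-fold lower number from compound 3 to compound 4 (0.05 log units; within the scatter)), so this first change on that ring can be read and shows no effect beyond it. The (4-methylphenyl)amino compound also stays within the scatter of both aryl compounds (a 1.6-fold higher number from compound 2 to compound 4 (0.20 log units; within the scatter); a 1.4-fold higher number from compound 1 to compound 4 (0.14 log units; within the scatter)). Nothing at hand offers an explanation for these results.

Going by these compounds, whether a carboxylic acid or a dimethylamino group in this place would move the number stays open. So does whether a methyl elsewhere on the ring would do so.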